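Swapping one aromatic group on an amide nitrogen

This account rests on a few compounds, and the source may have more. Where it says the series, first, only, none or still open, it means among the compounds named here.

compound 1 `CN(C)C(=O)c1cc2cnc(Nc3ccc(N)cn3)nc2n1C1CCCC1`: -21.2%
compound 2 `CN(C)C(=O)c1cc2cnc(Nc3ccc(NC(=O)C4(C(=O)Nc5cccc(O)c5)CC4)cc3)nc2n1C1CCCC1`: -19.8%
compound 3 `Nc1ccc(NC(=O)C2(C(=O)Nc3ccc(F)cc3)CC2)cc1F`: 21.7%

In a functional assay on SiHa cells (Homo sapiens) for inhibition, read by CCK-8 assay, with a stated time of 72 h, tested at 1 uM (a lower number here means less inhibition of growth, a higher number more inhibition of growth at the concentration tested), compound 2 gives -19.8% and sits within the scatter of compound 1 (-21.2%) while compound 3 (21.7%) lies higher, beyond the scatter. Compound 4 `CN(C)C(=O)c1cc2cnc(Nc3ccc(NC(=O)C4(C(=O)Nc5ccc(Cl)c(C(F)(F)F)c5)CC4)cc3)nc2n1C1CCCC1` carries 4-chloro-3-(trifluoromethyl)phenyl in place of 3-hydroxyphenyl on an amide-type nitrogen. For the measured compounds named here, no measured pair shows this change alone, so the size of the step is a judgement. Going by the values given here, compound 3 (21.7%) shows only that numbers above zero occur in this small set, so a moderate rise beyond the scatter is expected. The estimated move is upward (a number 24.8 percentage points higher from compound 2 to compound 4 (beyond the scatter)). For compound 4 the expected value is 5% with an estimated range (-22% to 35%).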

Compound 4, percent growth inhibition at one concentration: -11.2%
Compound 4: the middle estimate sits 16.2 percentage points above what was measured, and the stated range covers the measured number.
By their numbers in this assay, from the lowest: compounds 1, 2 and 4 (each within the scatter of the next); then compound 3.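

In this assay, putting 4-chloro-3-(trifluoromethyl)phenyl in place of 3-hydroxyphenyl on the amide-type nitrogen gives a number 8.6 percentage points higher from compound 2 to compound 4 (within the scatter), so this swap does not separate the two compounds at the concentration tested. The entering group has 0 hydrogen-bond donors and 0 hydrogen-bond acceptors, whereas the leaving group has 1 of each, yet the numbers remain within the scatter. Nothing available here bears on why this is so. From the compounds shown here alone, it remains open whether a phenyl group carrying an amine or a carboxylic acid would shift the number. The same question stands for a longer alkyl chain on this nitrogen.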